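The source may hold more compounds than are shown below. What is called first, only, known or untested is meant among the compounds shown, and "the series" means these compounds.

Measured so far in a functional assay on MDA-MB-231 cells (Homo sapiens) for cytotoxicity, read by sulforhodamine B assay, with a stated time of 48 h; on this read-out lower numbers stand for stronger inhibition of growth and higher numbers for weaker inhibition of growth:

- compound 1 `CCN(CC)CN1C(=O)/C(=N\c2nc3ccc(C)cc3s2)c2ccccc21` gives 32700 nM
- compound 2 `Cc1ccc2nc(/N=C3\C(=O)N(CN4CCCCC4)c4ccccc43)sc2c1` gives 34500 nM
- compound 3 `O=C1C(=O)N(CN2CCCCC2)c2cccc(Br)c21` gives 30200 nM

Compound 1 and compound 2 share one core and differ in a single place: diethylamino in place of piperidin-1-yl on a saturated chain carbon bound to an amide-type nitrogen in a ring. The step that goes with this change is a 1.1-fold lower number from compound 2 to compound 1 (0.02 log units; within the scatter). Compound 3 rests on another core; the difference between the core of compound 3 and the core of compound 2 is not broken down here. The number for compound 3 is the lowest of the three, yet its gaps to compound 1 and to compound 2 both lie within the scatter, so no order among the three can be read from these values.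

Compound 4 `CCN(CC)CN1C(=O)C(=O)c2c(Br)cccc21` has not yet been measured. It stands to compound 3 as compound 1 stands to compound 2: diethylamino in place of piperidin-1-yl on a saturated chain carbon bound to an amide-type nitrogen in a ring. The place of the change is described in the same words in both pairs, so this is the same change made once more, on the other core.

The expected step in this assay is therefore small, a 1.0-fold lower number from compound 3 to compound 4 (0.02 log units; within the scatter). Among the compounds with values here, that expectation rests on compound 2 and compound 1, where the same change gave a 1.1-fold lower number from compound 2 to compound 1 (0.02 log units; within the scatter), a step within the scatter, and on there being no second example to set against it. Compound 4 is estimated at 29000 nM in this assay. The estimate for compound 4 is expected to fall between 14000 nM and 60000 nM.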

Compound 4, concentration for 50% growth inhibition: 20200 nM
Estimate against measurement, compound 4: 1.4-fold (0.16 log units) above; low and high end bracket the measured number.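

Made on the second core, the exchange of piperidin-1-yl for diethylamino on a saturated chain carbon bound to an amide-type nitrogen in a ring gives a 1.5-fold lower number from compound 3 to compound 4 (0.17 log units; within the scatter) and so does not separate the two compounds in this assay. Within the data shown here, with only two pairs, both within the scatter, the series gives no sign that either amine is preferred, and it cannot show whether the same would hold on a third core or in another read-out. Within these limits, the change carries from one core to the other without a difference that can be read, and the two cores behave alike for this one exchange: the same change on two cores in this assay, a 1.1-fold lower number (0.02 log units; within the scatter) from compound 2 to compound 1 and a 1.5-fold lower number (0.17 log units; within the scatter) from compound 3 to compound 4, 1.4-fold (0.15 log units) apart, within the scatter of two such steps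

Still open, as far as these compounds go, is whether any amine on the same chain carbon would move the number beyond the scatter on either core, for example morpholin-4-yl, 4-methylpiperazin-1-yl or dimethylamino. Also open, from the compounds shown here alone, is what a longer chain between the amide-type nitrogen and the amine would do, and whether a carboxylic acid in place of the amine would leave the number where these pairs have it.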